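An isopropyl enters where compound 2 carries a hydrogen

The source may hold more compounds than are shown below. What is called first, only, known or untested is meant among the compounds shown, and "the series" means these compounds.

compound 1 `Cc1cc(Nc2nn(Cc3ccncc3)c(=O)c3ccccc23)n[nH]1` — > 30000 nM (a limit of the assay)
compound 2 `Cc1cc(Nc2nn(C)c(=O)c3ccccc23)n[nH]1` — > 30000 nM (a limit of the assay)

In a functional assay on MCF7 cells (Homo sapiens) for cytotoxicity (on this read-out higher numbers stand for weaker inhibition and lower numbers for stronger inhibition), compound 1 gives > 30000 nM, which is a limit of the assay and not a number. Compound 2 gives > 30000 nM, again a limit and not a number. Among the compounds with values here, the one step between them, a step that the two limits leave unreadable from compound 1 to compound 2, therefore has no readable size, and both values rest at the limit of > 30000 nM in this assay, at which 2 of the 2 values shown sit. Compound 3 `Cc1cc(Nc2nn(CC(C)C)c(=O)c3ccccc23)n[nH]1` differs from compound 2 by isopropyl in place of hydrogen on a saturated chain carbon bound to an aromatic nitrogen. Within the data shown here, no measured step shows what an isopropyl at this place does to the read-out, so no direction beyond the scatter can be expected from the data at hand. Compound 3 is therefore expected to stay at the limit, with an estimated step of a number no higher from compound 2 to compound 3 (the limit leaves the size open). The estimate for compound 3 is 30000 nM, expected between 10000 nM and 100000 nM, and most likely reported only as a limit.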

Compound 3, half-maximal inhibitory concentration: 4200 nM
Compound 3: middle estimate off by 7.1-fold (0.85 log units), on the high side; measured number below the stated range.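

In this assay this position turns out to respond to the read-out: isopropyl in place of hydrogen on a saturated chain carbon bound to an aromatic nitrogen gives an at least 7.1-fold lower number from compound 2 to compound 3 (0.85 log units; beyond the scatter) and so brings the series off its limit. At the same place, isopropyl in place of pyridin-4-yl gives an at least 7.1-fold lower number from compound 1 to compound 3 (0.85 log units; beyond the scatter) and points the same way. The step between compound 1 and compound 2 cannot be read, so only compound 3 gives a true number here, while the other two values are limits: the limit of > 30000 nM in this assay, at which 2 of the 3 values shown sit.

From the compounds shown here alone, the true size of both new steps stays open, since each starts from a limit. Also open, going by these compounds, is whether this effect is special to isopropyl or would also appear with a longer chain such as butyl, a cyclohexyl ring, or a chain ending in an amine or a carboxylic acid.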